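A few compounds are considered here, and "the series" means these few. Any claim that something is new, unique, unknown or untested is made for them only; others in the source may bear on it.

Measured so far, in a functional assay on PC-3 cells (Homo sapiens) for inhibition, read by MTT assay, with a stated time of 72 h, tested at 10 uM; a lower number here means less inhibition of growth, a higher number more inhibition of growth at the concentration tested:

compound 1, `O=C(/C=C/c1cc([N+](=O)[O-])ccc1Cl)/C=C/c1ccccc1Oc1ncnc2ccc(Cl)cc12` — 86.9%
compound 2, `O=C(/C=C/c1ccc(Oc2ncnc3ccc(Cl)cc23)cc1)/C=C/c1ccc(Cl)c(Cl)c1` — 33.5%

Compound 1 stands highest of the two numbers available. Its nearest neighbour, compound 2, sits a long way lower, and that gap lies beyond the scatter of this assay. For the measured compounds named here, compound 2 differs from compound 1 in more than one place, so no single step between them can be read off; the two values show only that the pair spans a wide range.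

Compound 3, `O=C(/C=C/c1ccccc1Oc1ncnc2ccc(Cl)cc12)/C=C/c1c(Cl)cccc1Cl`, has not yet been measured. It differs from compound 1 in one place: 2,6-dichlorophenyl in place of 2-chloro-5-nitrophenyl on a double-bonded chain carbon bound to a double-bonded chain carbon. Going by the values given here, no measured pair isolates this change. Compound 2 carries a dichlorophenyl ring and sits far lower, but its other differences cloud the comparison. Compound 3 is therefore expected to fall somewhat below compound 1, a step of a number 21.9 percentage points lower from compound 1 to compound 3 (beyond the scatter) in this assay, with wide uncertainty. The estimate for compound 3 is 65%, within a range from 35% to 90%.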

Compound 3, percent growth inhibition at one concentration: 70.1%
The estimate for compound 3 lay 5.1 percentage points below the measured number; measured number inside the range.
By their numbers in this assay, from the lowest: compound 2; then compound 3; then compound 1.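

In this assay, for the compounds shown here, 2,6-dichlorophenyl in place of 2-chloro-5-nitrophenyl on a double-bonded chain carbon bound to a double-bonded chain carbon gives a number 16.8 percentage points lower from compound 1 to compound 3 (beyond the scatter) as the first step that can be read on its own. The change is modest, and compound 3, with 70.1% in this assay, shows that substantial inhibition of growth at the concentration tested does not require the nitro group at this place. Nothing available explains the size of this step.

Whether the step follows the loss of the nitro group, the gain of a second chlorine, or both remains unresolved. On these data alone, it is also open how an amine or a methoxy group on this ring would behave at this place.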